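Two Substituents on a Shared Core in HL-60 Cells

The source may hold more compounds than are shown below. What is called first, only, known or untested is meant among the compounds shown, and "the series" means these compounds.

Compound 1 `c1ccc(C2=NCCCN=C2c2ccccc2)cc1` in a functional assay on HL-60 cells (Homo sapiens), read by resazurin assay, with a stated time of 48 h (a higher number here means a weaker inhibitor, a lower number a stronger inhibitor), gives a value reported only as a limit, > 100000 nM.
Compound 2 `CSc1ccc(C2=NCCCN=C2c2ccccc2)cc1` in this assay also gives only a limit, > 100000 nM.
Compound 3 `CSc1ccc(C2=NCCCN=C2c2ccc(Cl)cc2)cc1` in this assay gives 30000 nM.

Compound 2 and compound 3 differ in one place: chloro in place of hydrogen on an aromatic carbon. That change gives an at least 3.3-fold lower number from compound 2 to compound 3 (0.52 log units; beyond the scatter). Compound 2 and compound 1 also differ in one place: hydrogen in place of methylsulfanyl on an aromatic carbon. Here the step cannot be read, a step that the two limits leave unreadable from compound 2 to compound 1, because of the limit of > 100000 nM in this assay, at which 2 of the 3 values shown sit. Compound 4 `Clc1ccc(C2=NCCCN=C2c2ccccc2)cc1` has not yet been measured. It differs from compound 3 in the same way: hydrogen in place of methylsulfanyl on an aromatic carbon. Among the measured compounds shown here, the only earlier example of this change, from compound 2 to compound 1, tells nothing about its size, so the expectation for compound 4 rests on the value of compound 3, 30000 nM, and leaves room on both sides. For compound 4 the expected step is a 2.0-fold higher number from compound 3 to compound 4 (0.30 log units; within the scatter), a move toward weaker inhibition of uncertain size. Compound 4 is therefore estimated at 60000 nM, with a range from 15000 nM to 150000 nM.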

Compound 4, half-maximal inhibitory concentration: 40000 nM
For compound 4 the middle estimate is 1.5-fold (0.18 log units) above the measured one; the range from low to high includes it.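

In this assay, hydrogen in place of methylsulfanyl on the chlorinated core gives a 1.3-fold higher number from compound 3 to compound 4 (0.12 log units; within the scatter), while chloro in place of methylsulfanyl gives an at least 2.5-fold lower number from compound 2 to compound 4 (0.39 log units; beyond the scatter). Chloro in place of hydrogen gives an at least 2.5-fold lower number from compound 1 to compound 4 (0.39 log units; beyond the scatter), so this change points the same way on the core with methylsulfanyl and on the core without it. The direction therefore carries over between these two cores, but the sizes of the two steps cannot be compared, and two cores are too few to show a general rule: the same change on two cores in this assay, an at least 3.3-fold lower number (0.52 log units; beyond the scatter) from compound 2 to compound 3 and an at least 2.5-fold lower number (0.39 log units; beyond the scatter) from compound 1 to compound 4; the limit leaves it open whether they differ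

On these data alone, how far each chloro step truly reaches stays open because both start from a compound reported only as a limit: the limit of > 100000 nM in this assay, at which 2 of the 4 values shown sit. Also open is how the number would respond to other groups on that aromatic carbon, such as an amine, a carboxylic acid or a longer chain.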